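A few compounds are considered here, and "the series" means these few. Any claim that something is new, unique, unknown or untested is made for them only; others in the source may bear on it.

Compound 1 `Cc1nc(N)c2c(-c3ccco3)cn([C@@H]3O[C@H](CO)[C@@H](O)[C@H]3O)c2n1` is the starting point of this step. In an ADME assay on MRC5 cells (Homo sapiens), read by MTT assay, with a stated time of 72 h (a lower number here means a stronger inhibitor, a higher number a weaker inhibitor), compound 1 gives > 100000 nM, which is a limit of the assay rather than a number. Among the measured compounds shown here, compound 2 `Cc1ncnc2c1c(-c1cccs1)cn2[C@@H]1O[C@H](CO)[C@@H](O)[C@H]1O` is the only other measured member of the series. In this assay compound 2 gives > 100000 nM, again a limit of the assay. For the measured compounds named here, both values shown thus sit at the limit of > 100000 nM in this assay, at which 2 of the 2 values shown sit, so compound 1 stands level with the one other measured compound and no difference between the two can be read.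

Compound 3 `Cc1nc(N)c2c(-c3ccsc3)cn([C@@H]3O[C@H](CO)[C@@H](O)[C@H]3O)c2n1` is not yet measured. It differs from compound 1 by thiophen-3-yl in place of furan-2-yl on an aromatic carbon. Going by the values given here, no step between two measured compounds is at hand, so nothing sizes this change. Compound 1 gives only a limit; the estimate for compound 3 is 150000 nM with a range of 50000 nM to 500000 nM. The expected step that the limit leaves unreadable from compound 1 to compound 3 is none beyond the scatter, with a limit again the most likely report.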

Compound 3, half-maximal inhibitory concentration: > 100000 nM
Compound 3 gave a limit, no number; the forecaster's own chance of this, stated with the estimate: 85%; the middle value does not contradict the limit.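

Among the compounds shown here, no step from compound 1 to compound 3 can be read, because both compounds give only a limit in this assay: the limit of > 100000 nM in this assay, at which 3 of the 3 values shown sit.

The compounds shown leave open whether any change on the shared core gives a measured number that could be compared.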